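Swapping the methylsulfanyl group of compound 3 for chlorine

The source may hold more compounds than are shown below. What is called first, only, known or untested is meant among the compounds shown, and "the series" means these compounds.

Three nucleoside-like compounds share one core and differ only in the group attached to an aromatic carbon. Compound 1 `OC[C@H]1O[C@@H](n2cnc3c(NCc4ccccc4)nccc32)C[C@@H]1O` carries a benzylamino group there, and in a functional assay (Homo sapiens) for inhibition of Nucleic Acid, tested at 100 uM (on this read-out higher numbers stand for more inhibition at the one concentration tested (going by the name of the read-out) and lower numbers for less inhibition), compound 1 gives 15%. Compound 2 `[N-]=[N+]=Nc1nccc2c1ncn2[C@H]1C[C@H](O)[C@@H](CO)O1` carries an azido group, and in this assay compound 2 gives 4%. Compound 3 `CSc1nccc2c1ncn2[C@H]1C[C@H](O)[C@@H](CO)O1` carries a methylsulfanyl group, and in this assay compound 3 gives 36%, the highest of the three numbers; its nearest neighbour is compound 1 and its furthest is compound 2, both beyond the scatter.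

Compound 4 `OC[C@H]1O[C@@H](n2cnc3c(Cl)nccc32)C[C@@H]1O` is the next step from compound 3, and the change is chloro in place of methylsulfanyl on an aromatic carbon. Among the compounds with values here, two measured steps bear on it, since both end in the methylsulfanyl compound: a number 21 percentage points higher from compound 1 to compound 3 (beyond the scatter) and a number 32 percentage points higher from compound 2 to compound 3 (beyond the scatter). Both show that the methylsulfanyl group sits at the top of this small set, and that replacing it with either of two other groups lowers the number in this assay. A drop is therefore expected when chloro takes its place, though its size cannot be fixed from only two prior replacements. Compound 4 is estimated to give 20%, within a range from 5% to 38%. That estimate means an expected step of a number 16 percentage points lower from compound 3 to compound 4 (beyond the scatter).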

Compound 4, a percentage reported as inhibition, at one concentration (the size of the read-out at that concentration, not a potency): 5%
Compound 4: the middle estimate sits 15 percentage points above what was measured; measured number inside the range.
By their numbers in this assay, from the lowest: compounds 2, 4 and 1 (each within the scatter of the next, the first and the last beyond it); then compound 3.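

With chloro, a third group now stands in place of methylsulfanyl on this aromatic carbon, and the change gives a number 31 percentage points lower from compound 3 to compound 4 (beyond the scatter), so the loss seen with benzylamino and azido also appears with a lone chlorine atom. Chloro does not set itself apart from those two groups: the other comparisons give a number 1 percentage points higher from compound 2 to compound 4 (within the scatter) and a number 10 percentage points lower from compound 1 to compound 4 (within the scatter), which leaves methylsulfanyl as the only one of the four groups clearly ahead in this assay, with no compound here going against that. Nothing in the available data explains why this one group stands apart.

Within the data shown here, only one group joined through sulfur appears here, so it stays open whether the higher number goes with the sulfur atom, with the methyl on it, or with the group as a whole; ethylsulfanyl, methoxy or a plain methyl group at this carbon would help separate these possibilities. Even compound 3 reaches only 36% at the single concentration tested, and whether any other group at this position could go beyond it remains unknown.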